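The source may hold more compounds than are shown below. What is called first, only, known or untested is meant among the compounds shown, and "the series" means these compounds.

Among the compounds with values here, compound 3 `Cc1c(/N=C/c2ccc(Cl)cc2Cl)c(=O)n(-c2ccccc2)n1C` gives 269000000 nM in a functional assay on HCT-116 cells (Homo sapiens) for cytotoxicity, read by MTT assay, with a stated time of 72 h (a higher number here means a weaker inhibitor, a lower number a stronger inhibitor), the lowest of the three numbers so far. Compound 2 `Cc1c(/N=C/c2ccc(Cl)cc2)c(=O)n(-c2ccccc2)n1C` gives 589000000 nM, and compound 1 `Cc1c(/N=C/c2ccccc2Cl)c(=O)n(-c2ccccc2)n1C` gives 851000000 nM. The two steps into compound 3 both lowered the number: a 3.2-fold lower number from compound 1 to compound 3 (0.50 log units; beyond the scatter) and a 2.2-fold lower number from compound 2 to compound 3 (0.34 log units; beyond the scatter). The step between the two monochloro compounds, a 1.4-fold lower number from compound 1 to compound 2 (0.16 log units; within the scatter), stays within the scatter.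

Compound 4 `Cc1c(/N=C/c2ccc(O)cc2)c(=O)n(-c2ccccc2)n1C` differs from compound 3 by 4-hydroxyphenyl in place of 2,4-dichlorophenyl on a carbon with a double bond to nitrogen. Within the data shown here, both chlorines are thereby lost, and a hydroxyl comes in for which no measured compound offers a comparison. Among the measured compounds shown here, the steps that bear on it are those in which chloro was removed in the reverse sense, each raising the number modestly, so a higher number is expected for compound 4 than for compound 3, with the hydroxyl adding uncertainty in either direction. The step from compound 3 to compound 4 is therefore estimated at a 3.3-fold higher number from compound 3 to compound 4 (0.52 log units; beyond the scatter). Compound 4 is expected to give about 900000000 nM, within a range from 300000000 nM to 2700000000 nM.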

Compound 4, half-maximal inhibitory concentration: 646000000 nM
Compound 4: the middle estimate sits 1.4-fold (0.14 log units) above what was measured; low and high end bracket the measured number.
By their numbers in this assay, from the lowest: compound 3; then compounds 2, 4 and 1 (each within the scatter of the next).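

Swapping chloro for hydroxy at this place, on a carbon with a double bond to nitrogen, leaves the number in the same range as a single chlorine does, with a 1.1-fold higher number from compound 2 to compound 4 (0.04 log units; within the scatter) and a 1.3-fold lower number from compound 1 to compound 4 (0.12 log units; within the scatter) both falling within the scatter. Compound 3 alone stands apart from the hydroxy compound, with a 2.4-fold higher number from compound 3 to compound 4 (0.38 log units; beyond the scatter) beyond the scatter but still modest, so among these compounds 4-hydroxyphenyl is set apart only from 2,4-dichlorophenyl. No measured evidence is at hand to explain these steps.

The compounds shown leave open whether an amine or a carboxylic acid in place of the hydroxy would also stay level with compound 4. As far as these compounds go, it also remains open whether a second group other than chloro, such as a methoxy, would lower the number as the second chlorine did in compound 3.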